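The source may report more compounds than this note shows. Statements on the series, on what has been measured and on what is new or still open speak of the compounds shown alone.

Measured in a functional assay on HT-29 cells (Homo sapiens) for cytotoxicity, read by MTT assay, with a stated time of 24 h, tested at 16 ug/mL; a higher number here means a stronger effect of the compound at the concentration tested, a lower number a weaker effect:
- compound 1 `Cc1ccc2oc(SCC(=O)Nc3ccc(-c4nc(-c5ccccc5)c(-c5ccccc5)n4C)cc3)nc2c1`, 37.7%
- compound 2 `Cn1nnnc1SCC(=O)Nc1ccc(-c2nc(-c3ccccc3)c(-c3ccccc3)n2C)cc1`, 72.5%

Among the compounds with values here, compound 2 stands highest of the two numbers in this assay; its only neighbour is compound 1, and the gap between them, a number 34.8 percentage points higher from compound 1 to compound 2 (beyond the scatter), lies beyond the scatter and counts as large. Compound 3 `CN(C)/C=C/N1CCN(CC(=O)Nc2ccc(-c3nc(-c4ccccc4)c(-c4ccccc4)n3C)cc2)CC1` is the next compound of the series, not yet measured in this assay. Its difference from compound 2: 4-(2-(dimethylamino)ethenyl)piperazin-1-yl in place of (1-methyl-1H-tetrazol-5-yl)sulfanyl on a saturated chain carbon bound to a carbonyl carbon.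

Within the data shown here, only one measured step bears on this, a number 34.8 percentage points higher from compound 1 to compound 2 (beyond the scatter), and it exchanged one ring on the sulfur for another while the sulfanyl link itself stayed. The change to compound 3 goes further: the whole (1-methyl-1H-tetrazol-5-yl)sulfanyl group leaves, and a six-membered non-aromatic ring with two hetero atoms enters in its place on the saturated chain carbon bound to the carbonyl carbon. Among the measured compounds shown here, no measured pair covers such a change, so the direction is open; the one known step shows only that this position moves the read-out strongly. The step from compound 2 to compound 3 is therefore expected to be a number 22.5 percentage points lower from compound 2 to compound 3 (beyond the scatter), with wide uncertainty. For compound 3 the estimate in this assay is 50%, ranging from 20% to 80%.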

Compound 3, a percentage reported as activity, at one concentration (the size of the read-out at that concentration, not a potency): 28.2%
Compound 3: middle estimate off by 21.8 percentage points, on the high side, within the range that was stated.
By their numbers in this assay, from the lowest: compounds 3 and 1 (each within the scatter of the next); then compound 2.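

In this assay, the saturated chain carbon bound to a carbonyl carbon responds strongly not only when the ring on the sulfur is exchanged but also when the whole sulfanyl group is replaced by 4-(2-(dimethylamino)ethenyl)piperazin-1-yl, with a number 44.3 percentage points lower from compound 2 to compound 3 (beyond the scatter). The same replacement set against the (5-methyl-1,3-benzoxazol-2-yl)sulfanyl group gives a number 9.5 percentage points lower from compound 1 to compound 3 (within the scatter), so the sulfanyl link alone does not carry the high read-out: compound 1 keeps that link and compound 3 lacks it, yet the two cannot be separated, and among these three compounds only the (1-methyl-1H-tetrazol-5-yl)sulfanyl group of compound 2 stands apart. No measurement at hand accounts for this difference.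

Open, on these data alone, is whether the piperazine ring or the 2-(dimethylamino)ethenyl part sets the read-out of compound 3, a question that a plain piperazin-1-yl or a morpholin-4-yl on the same carbon would address. Also open, as far as these compounds go, is whether the 1-methyl-1H-tetrazol-5-yl ring depends on the sulfur, which the same ring joined through an oxygen atom or a methylene link would test.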